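A few compounds are considered here, and "the series" means these few. Any claim that something is new, unique, unknown or untested is made for them only; others in the source may bear on it.

Working notes on the series. Compound 1 `FC(F)(F)c1nc2c(Br)cccc2c(Cl)c1Br` is the parent of the step followed here. In an assay for inhibition of ectonucleoside triphosphate diphosphohydrolase 8 (Homo sapiens), read by malachite green, with a stated time of 10 min (on this read-out lower numbers stand for stronger inhibition and higher numbers for weaker inhibition), compound 1 gives only a limit of the assay, > 300000 nM. Compound 2 `Fc1ccc(-c2c(C(F)(F)F)nc3c(-c4ccc(F)cc4)cccc3c2-c2ccc(F)cc2)cc1` likewise gives only a limit, > 300000 nM. Compound 3 `COc1ccc(OC)c(-c2cccc3c(Cl)c(Br)c(C(F)(F)F)nc23)c1` also gives only a limit, > 300000 nM. Compound 1 therefore stands at the same limit as all others shown (the limit of > 300000 nM in this assay, at which 3 of the 3 values shown sit), so no step between measured compounds can be read off. Compound 4 `FC(F)(F)c1nc2c(-c3ccsc3)cccc2c(Cl)c1Br` carries the change (thiophen-3-yl in place of bromo on an aromatic carbon), thiophen-3-yl in place of bromo on an aromatic carbon. With every value shown sitting at the limit, no direction can be drawn from the measured compounds; the step from compound 1 to compound 4 is expected to be a number no higher from compound 1 to compound 4 (the limit leaves the size open), none beyond the scatter. Compound 4 is accordingly estimated at 300000 nM, within 50000 nM to 1000000 nM, with a high chance that this assay again reports only a limit.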

Compound 4, half-maximal inhibitory concentration: > 300000 nM
Compound 4 gave a limit, no number; the forecaster's own chance of this, stated with the estimate: 75%; the middle value lies on the limit itself.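

In this assay no step can be read from compound 1 to compound 4, because both sit at the same limit: the limit of > 300000 nM in this assay, at which 4 of the 4 values shown sit. The compounds shown leave open how strongly any of them truly inhibits, and which change to the shared core would give a measurable value.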